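Series notes: amide carbon substituent on the shared core of compound 1

A few compounds are considered here, and "the series" means these few. Any claim that something is new, unique, unknown or untested is made for them only; others in the source may bear on it.

In a functional assay on cells for positive allosteric modulation of metabotropic glutamate receptor 5 (Rattus norvegicus), read by calcium flux (on this read-out lower numbers stand for an effect already at smaller amounts and higher numbers for an effect only at larger amounts of compound), the measured compounds stand as follows:

compound 1 `O=C(Nc1cc(-c2ccccc2)nn1-c1ccccc1)c1cccc([N+](=O)[O-])c1`: 39 nM
compound 2 `O=C(Nc1cc(-c2ccccc2)nn1-c1ccccc1Cl)c1ccccc1`: 62 nM
compound 3 `COc1cccc(-n2nc(-c3ccccc3)cc2NC(=O)c2ccccc2)c1`: 570 nM

Compound 1 gives the lowest of the three numbers. Compound 2 lies within the scatter of it, so the two cannot be ordered. Compound 3 stands furthest from compound 1, beyond the scatter. Within the data shown here, the only single-place step in the set is a 9.2-fold higher number from compound 2 to compound 3 (0.96 log units; beyond the scatter), and it concerns the group on the aromatic nitrogen, which compound 1 and compound 4 share unchanged; it therefore says nothing about the change at hand.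

Compound 4 `O=C(CC1CCCC1)Nc1cc(-c2ccccc2)nn1-c1ccccc1` differs from compound 1 at the carbonyl carbon: cyclopentylmethyl in place of 3-nitrophenyl on a carbonyl carbon. Among the measured compounds shown here, no measured compound in the set carries anything other than an aromatic ring on that carbonyl carbon, so there is no step to draw on, and the expectation for compound 4 rests on the structural change alone, with wide uncertainty. A weakening step, a 5.1-fold higher number from compound 1 to compound 4 (0.71 log units; beyond the scatter), is expected, though a result within the scatter of compound 1 cannot be excluded. For compound 4 the estimate in this assay is 200 nM, with a range from 40 nM to 1500 nM.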

Compound 4, half-maximal effective concentration: 350 nM
Estimate against measurement, compound 4: 1.8-fold (0.24 log units) below, within the range that was stated.
By their numbers in this assay, from the lowest: compounds 1 and 2 (each within the scatter of the next); then compounds 4 and 3 (each within the scatter of the next).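

Among these compounds, this is the first non-aromatic group on the carbonyl carbon, and in this assay cyclopentylmethyl in place of 3-nitrophenyl gives a 9.0-fold higher number from compound 1 to compound 4 (0.95 log units; beyond the scatter) as a step beyond the scatter, so this position responds to the change. Among the compounds shown here, the step exchanges several features at once, since the entering group has a non-aromatic five-membered ring and fewer heavy atoms and lacks the hydrogen-bond acceptors of the 3-nitrophenyl group, and the single step cannot divide its size among them. Nothing available bears on why the number rises.

Still open, from the compounds shown here alone, is whether the aromatic ring or the nitro group accounts for the step, which plain phenyl and cyclohexyl on this carbonyl carbon of the core of compound 1 could separate. Also open, going by these compounds, is how an amine or a longer chain at this place would read.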